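Amide variation on the shared piperidine carboxamide core

The compounds below may be only part of what the source reports. "The series", "measured", "known", "first", "only" and "open" are said of these compounds alone.

Compound 1 `CN(Cc1ccccc1)C(=O)C1CCN(C(=O)c2ccc(S(C)(=O)=O)c([N+](=O)[O-])c2)CC1` and compound 2 `CC1Cc2ccccc2N1C(=O)C1CCN(C(=O)c2ccc(S(C)(=O)=O)c([N+](=O)[O-])c2)CC1` share the same core and differ only in the amine attached to the carbonyl carbon. In an assay on isolated protein for inhibition of vitamin D3 receptor (Homo sapiens), read by fluorescence polarization (on this read-out higher numbers stand for weaker inhibition and lower numbers for stronger inhibition), compound 1 gives > 60000 nM, which is a limit of the assay and not a number. In this assay compound 2 likewise gives > 60000 nM, again a limit of the assay rather than a number. The step that the two limits leave unreadable from compound 1 to compound 2 cannot be read because the limit of > 60000 nM in this assay, at which 2 of the 2 values shown sit, shows both ends sitting at the limit. For the measured compounds named here, compound 2 therefore stands at the limit in this assay, and so does the only other measured compound.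

Compound 3 `CC(C)N(C(=O)C1CCN(C(=O)c2ccc(S(C)(=O)=O)c([N+](=O)[O-])c2)CC1)C(C)C` is yet to be measured; it differs from compound 2 by diisopropylamino in place of 2-methyl-2,3-dihydro-1H-indol-1-yl on a carbonyl carbon. Going by the values given here, the only measured step at the same position is the unreadable one, so no size or direction can be drawn from it, and nothing in the two values indicates that a ring-free amine would move the read-out away from the limit. Compound 3 is accordingly expected to stay at the limit, with an estimate of 80000 nM spanning 20000 nM to 300000 nM. The step that the limit leaves unreadable from compound 2 to compound 3 that this estimate implies is expected to be none beyond the scatter.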

Compound 3, half-maximal inhibitory concentration: > 60000 nM
Compound 3 was reported as a limit; the forecaster's own chance of this, stated with the estimate: 85%; the middle value does not contradict the limit.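

In this assay compound 3 gives > 60000 nM as a limit of the assay and not a number. No step among compound 1, compound 2 and compound 3 can be read, so this result adds no new step: the limit of > 60000 nM in this assay, at which 3 of the 3 values shown sit.

The compounds shown leave open which amine on the carbonyl carbon of the shared core, if any, gives a readable value in this assay and so a step of readable size.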